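The compounds below may be only part of what the source reports. "The series", "measured", "known", "first", "only" and "open" are said of these compounds alone.

Of the compounds shown here, three sharing one core have been tested in a functional assay on DU-145 cells (Homo sapiens) for inhibition, read by trypan blue exclusion, with a stated time of 96 h; a lower number here means a stronger inhibitor of growth, a higher number a weaker inhibitor of growth. Compound 1 `COc1cc(OC)c(/C=C(/SCc2ccc(Cl)c(Cl)c2)C(=O)c2ccc(Cl)cc2)c(OC)c1`, which carries a (3,4-dichlorobenzyl)sulfanyl group, gives 10000 nM. Compound 2 `COc1cc(OC)c(/C=C(\C(=O)c2ccc(Cl)cc2)S(=O)(=O)c2ccc(Br)cc2)c(OC)c1`, which carries a (4-bromophenyl)sulfonyl group, gives > 100000 nM, and this is a limit of the assay, not a number. Compound 3 `COc1cc(OC)c(/C=C(\C(=O)c2ccc(Cl)cc2)S(=O)(=O)Cc2ccc(F)cc2)c(OC)c1`, with a (4-fluorobenzyl)sulfonyl group, gives 25000 nM, the higher of the two true numbers, which makes it a weaker growth inhibitor than compound 1.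

The next compound is compound 4 `COc1cc(OC)c(/C=C(\C(=O)c2ccc(Cl)cc2)S(=O)(=O)c2ccc(C)cc2)c(OC)c1`, which has 4-methylphenyl in place of 4-fluorobenzyl on a sulfonyl sulfur. The entering group is a substituted phenyl, as in compound 2, not a benzyl. The most relevant measurement is therefore an at least 4.0-fold lower number from compound 2 to compound 3 (0.60 log units; beyond the scatter), which swapped 4-bromophenyl for 4-fluorobenzyl on the same sulfur. Within the data shown here, compound 4 runs that change roughly in reverse, though no measured step covers methyl in place of bromo. The comparison an at least 10-fold higher number from compound 1 to compound 2 (1.00 log units; beyond the scatter) also marks the phenyl sulfonyl compound as the weak one, whereas a 2.5-fold higher number from compound 1 to compound 3 (0.40 log units; beyond the scatter) is smaller. A move towards a weaker inhibitor is thus expected in this assay. The estimated change is a 2.4-fold higher number from compound 3 to compound 4 (0.38 log units; beyond the scatter). For compound 4 the expected value is 60000 nM, with an estimated range from 20000 nM to 150000 nM.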

Compound 4, concentration for 50% growth inhibition: 25000 nM
The estimate for compound 4 lay 2.4-fold (0.38 log units) above the measured number; the measured number falls inside the stated range.
By their numbers in this assay, from the lowest: compound 1; then compounds 3 and 4 (each within the scatter of the next). At a limit, above all of these: compound 2.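

In this assay, no change at the digits printed from compound 3 to compound 4 (within the scatter), so on this sulfonyl sulfur 4-methylphenyl and 4-fluorobenzyl cannot be told apart, and a phenyl ring bound directly to the sulfur does not by itself go with the very weak result of compound 2. Instead, the sharp drop among the phenyl sulfonyl compounds appears with a single change, methyl in place of bromo on an aromatic carbon, with an at least 4.0-fold lower number from compound 2 to compound 4 (0.60 log units; beyond the scatter), while a 2.5-fold higher number from compound 1 to compound 4 (0.40 log units; beyond the scatter) matches the gap already seen for compound 3. Compound 2 rests on a limit of the assay rather than a true number, so its steps give only a minimum size: the limit of > 100000 nM in this assay, at which 1 of the 4 values shown sits.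

The compounds shown leave open whether another group on that aromatic carbon, such as an amine or a carboxylic acid, would keep the sulfonyl compound in the range of compound 4 or take it to the limit of compound 2. They also do not separate the sulfanyl-to-sulfonyl change from the change of the attached ring, since the step from compound 1 makes both at once.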